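Cytotoxicity notes: aryl swap on the shared core

A few compounds are considered here, and "the series" means these few. Any claim that something is new, unique, unknown or untested is made for them only; others in the source may bear on it.

Measured compounds:
compound 1 `CNC(=O)c1cc(Oc2ccc(NC(=O)c3nn(-c4ccccc4OC(F)(F)F)c(=O)cc3C)cc2F)ccn1`
compound 2 `Cc1cc(=O)n(-c2ccccc2OC(F)(F)F)nc1C(=O)Nc1ccc(Oc2ncnc3ccsc23)cc1`
compound 3 `Cc1cc(=O)n(-c2ccccc2OC(F)(F)F)nc1C(=O)Nc1ccc(Oc2ncnc3ccsc23)c(F)c1`

In a functional assay on HepG2 cells (Homo sapiens) for cytotoxicity, read by MTT assay, with a stated time of 72 h (a lower number here means a stronger inhibitor, a higher number a weaker inhibitor), compound 1 reaches only the assay limit of > 40000 nM, a limit rather than a number (the limit of > 40000 nM in this assay, at which 1 of the 3 values shown sits). In this assay compound 2 gives 25000 nM and compound 3 gives 15700 nM. Compound 3 and compound 2 sit within the scatter of each other (a 1.6-fold lower number from compound 2 to compound 3 (0.20 log units; within the scatter)), so neither can be set apart. The swap on the ether oxygen gave an at least 2.5-fold lower number from compound 1 to compound 3 (0.40 log units; beyond the scatter), at least modest. Compound 4 `Cc1cc(=O)n(-c2ccc(F)c(F)c2)nc1C(=O)Nc1ccc(Oc2ncnc3ccsc23)c(F)c1` differs from compound 3 by 3,4-difluorophenyl in place of 2-(trifluoromethoxy)phenyl on an aromatic nitrogen. Neither measured step touches this position, so nothing bears on it directly, and a change beyond the scatter in this assay is not expected in either direction. Compound 4 is estimated at 18000 nM, range 6000 nM to 55000 nM, meaning a 1.1-fold higher number from compound 3 to compound 4 (0.06 log units; within the scatter).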

Compound 4, half-maximal inhibitory concentration: 6930 nM
Compound 4: middle estimate off by 2.6-fold (0.41 log units), on the high side, within the range that was stated.
By their numbers in this assay, from the lowest: compound 4; then compounds 3 and 2 (each within the scatter of the next). At a limit, above all of these: compound 1.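

In this assay, among these compounds, 3,4-difluorophenyl in place of 2-(trifluoromethoxy)phenyl on the aromatic nitrogen gave a 2.3-fold lower number from compound 3 to compound 4 (0.36 log units; beyond the scatter) and so shows that this position, untouched by the earlier steps, can move the number. The step is modest and rests on one pair on a single background. Nothing shown here accounts for this step.

As far as these compounds go, whether the step comes from losing the trifluoromethoxy group or from gaining the two fluorines stays open. Also open, from the compounds shown here alone, is how an amine or a carboxylic acid on this phenyl ring would read.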